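Lengthening the chain of compound 1

The source may hold more compounds than are shown below. What is called first, only, known or untested is meant among the compounds shown, and "the series" means these compounds.

Measured in a functional assay on SW480 cells (Homo sapiens) for antiproliferative activity, read by MTT assay, with a stated time of 48 h (a lower number here means a stronger inhibitor, a higher number a weaker inhibitor), each value a limit and not a number:
compound 1 `CCCCCCC(CCO)n1cnc2c(NC)ncnc21`: > 50000 nM
compound 2 `CCCCCCC(CCO)n1cnc2c(N(C)C)ncnc21`: > 50000 nM
compound 3 `CCCCCCC(CCO)n1cnc2c(N)ncnc21`: > 50000 nM

Compound 1 has no number, only (the limit of > 50000 nM in this assay, at which 3 of the 3 values shown sit). Compound 4 `CCCCCCCCCCC(CCO)n1cnc2c(NC)ncnc21` differs from compound 1 as follows: butyl in place of hydrogen on a saturated chain carbon, seven bonds along the chain from an aromatic nitrogen. Within the data shown here, three measured steps bear on the nitrogen on the aromatic ring and not on the chain: a step that the two limits leave unreadable from compound 1 to compound 2, a step that the two limits leave unreadable from compound 1 to compound 3 and a step that the two limits leave unreadable from compound 2 to compound 3. They offer no size to carry over. A step towards stronger inhibition in this assay is expected from the structural change alone, and its size is uncertain. The estimate means an at least 1.6-fold lower number from compound 1 to compound 4 (0.22 log units; that floor lies within the scatter), an expected shift of uncertain size. For compound 4 the expected value is 30000 nM, with an estimated range from 10000 nM to 60000 nM.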

Compound 4, half-maximal inhibitory concentration: 12000 nM
Beside the measured number, compound 4's estimate is 2.5-fold (0.40 log units) above it, and the stated range covers the measured number.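

In this assay, butyl in place of hydrogen on this saturated chain carbon gives the first readable step, an at least 4.1-fold lower number from compound 1 to compound 4 (0.61 log units; beyond the scatter), and compound 4 is the first compound shown with a number and not a limit. Among these compounds, the steps among compound 1, compound 2 and compound 3 cannot be read, so only this chain change shows a size, and that size is a floor: the limit of > 50000 nM in this assay, at which 3 of the 4 values shown sit.

Open, as far as these compounds go, is whether a still longer chain, or a chain carrying a carboxylic acid, would lower the number further. Also open, from the compounds shown here alone, is whether amino or dimethylamino in place of the methylamino of compound 4 would shift it.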